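Ring-nitrogen substituent series: compound 3 to compound 4

The source may report more compounds than this note shows. Statements on the series, on what has been measured and on what is new or still open speak of the compounds shown alone.

Compound 3 `CN1CCC(CCCn2c(COc3ccccc3)nc3c(OCCCN4CCCCC4)cccc32)CC1` gives 1.62 nM in an in vitro assay on AV12 cells for binding affinity to Neuropeptide Y receptor type 1 (Homo sapiens) (a higher number here means a weaker inhibitor, a lower number a stronger inhibitor), the highest of the three measured numbers. Compound 1 `c1ccc(OCc2nc3c(OCCCN4CCCCC4)cccc3n2CCCC2CCN(CCC3CCCCC3)CC2)cc1` gives 0.285 nM in this assay, and compound 2 `c1ccc(OCc2nc3c(OCCCN4CCCCC4)cccc3n2CCCC2CCN(CCCN3CCCCC3)CC2)cc1` gives 0.106 nM. Both substituted compounds stand beyond the scatter from compound 3: a 5.7-fold higher number from compound 1 to compound 3 (0.75 log units; beyond the scatter), and a 15-fold higher number from compound 2 to compound 3 (1.18 log units; beyond the scatter). Between the two substituted compounds the gap is a 2.7-fold lower number from compound 1 to compound 2 (0.43 log units; beyond the scatter).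

Compound 4 `CC(C)CCN1CCC(CCCn2c(COc3ccccc3)nc3c(OCCCN4CCCCC4)cccc32)CC1` differs from compound 3 by isobutyl in place of hydrogen on a saturated chain carbon bound to an amine nitrogen in a ring. The two steps that bear on this both read hydrogen entering on the same saturated chain carbon bound to the amine nitrogen in the ring, and in both the number rose; read in reverse, a group entering there lowered the number, modestly for cyclohexylmethyl and largely for 2-(piperidin-1-yl)ethyl. Isobutyl, like cyclohexylmethyl, carries no ring and no hydrogen-bond acceptor, and the cyclohexylmethyl step is the closer guide. A lowering in this assay is therefore expected, of roughly the modest kind: compound 4 is estimated at 0.5 nM, between 0.15 nM and 1.6 nM, a step of a 3.2-fold lower number from compound 3 to compound 4 (0.51 log units; beyond the scatter).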

Compound 4, inhibition constant: 0.29 nM
The estimate for compound 4 lay 1.7-fold (0.24 log units) above the measured number; measured number inside the range.
By their numbers in this assay, from the lowest: compound 2; then compounds 1 and 4 (each within the scatter of the next); then compound 3.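

In this assay, isobutyl on the saturated chain carbon bound to an amine nitrogen in a ring gives a step of the modest kind (a 5.6-fold lower number from compound 3 to compound 4 (0.75 log units; beyond the scatter)), so a group with no ring and 4 carbon heavy atoms is enough for a lower number than hydrogen gives here. Compounds 1 and 4 cannot be told apart (a 1.0-fold higher number from compound 1 to compound 4 (0.01 log units; within the scatter)), so isopropyl in place of cyclohexyl at the chain end leaves the number within the scatter. Compound 2 stays apart from compound 4 (a 2.7-fold higher number from compound 2 to compound 4 (0.44 log units; beyond the scatter)), which leaves the 2-(piperidin-1-yl)ethyl group alone with the lowest number of this set.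

No measurement among the compounds shown accounts for these steps. From the compounds shown here alone, whether the lower number of compound 2 follows the ring amine at the chain end remains open, and a 2-(morpholin-4-yl)ethyl or 2-(dimethylamino)ethyl group in the same place would bear on that.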